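Ethyl amidine extension on a pyrazole series at the assay limit

A few compounds are considered here, and "the series" means these few. Any claim that something is new, unique, unknown or untested is made for them only; others in the source may bear on it.

Compound 1, `CN/C=N/c1cc(-c2ccccc2)nn1-c1ccccc1`: > 50000 nM in a functional assay on NCI-H661 cells (Homo sapiens) for inhibition, read by MTT assay, with a stated time of 72 h (on this read-out higher numbers stand for weaker inhibition of growth and lower numbers for stronger inhibition of growth), a limit rather than a number
Compound 2, `CN/C(C)=N/c1cc(-c2ccccc2)nn1-c1ccccc1`: > 50000 nM in this assay, again a limit rather than a number

Compound 2 stands at the limit of this assay, where both measured values sit, as the limit of > 50000 nM in this assay, at which 2 of the 2 values shown sit, shows. Among the measured compounds shown here, the only measured step, a step that the two limits leave unreadable from compound 1 to compound 2, is therefore unreadable; it exchanges one open-chain group for another on an aromatic carbon of the shared core and says nothing about size or direction.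

Compound 3, `CC/C(=N\c1cc(-c2ccccc2)nn1-c1ccccc1)NC`, differs from compound 2 by methyl in place of hydrogen on a saturated chain carbon bound to a carbon with a double bond to nitrogen, which read one bond further out is methyl to ethyl. For the measured compounds named here, no measured step bears on this change beyond the unreadable one, and the two values reported give no foothold for a direction.

The expectation for the step from compound 2 to compound 3 in this assay is therefore none beyond the scatter, as a step that the limit leaves unreadable from compound 2 to compound 3 expresses. Compound 3 is accordingly expected to give 80000 nM in this assay, with an estimated range from 20000 nM to 300000 nM, and most likely the assay will again report only a limit.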

Compound 3, concentration for 50% growth inhibition: > 50000 nM
Compound 3: no number, only a limit (the forecaster's own chance of this, stated with the estimate: 85%); the middle value is on the limit's open side.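

Compound 1, compound 2 and compound 3 all stand at a limit rather than at a number in this assay, so no step among them can be read: the limit of > 50000 nM in this assay, at which 3 of the 3 values shown sit.

The compounds shown leave open whether the change from methyl to ethyl affects growth inhibition at all, and how far any of the three lies beyond that limit.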